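The compounds below may be only part of what the source reports. "The series", "measured", "known", "first", "only" and "open" are said of these compounds alone.

Compound 1 `CN1CCN(CCCCn2c3c(c4ccccc42)C(=O)c2c[n+]([O-])c4ccccc4c2C3=O)CC1` gives 100 nM in the assay below
Compound 2 `CC1(C)O[C@@H](CO)[C@H](Cn2cc(Cn3c4c(c5ccccc53)C(=O)c3c[n+]([O-])c5ccccc5c3C4=O)nn2)O1` gives > 1000 nM in the assay below
Compound 3 `O=C1c2c[n+]([O-])c3ccccc3c2C(=O)c2c1c1ccccc1n2Cc1cn([C@H]2C[C@H](O)[C@@H](CO)O2)nn1` gives 620 nM in the assay below

All three were tested in a functional assay on SH-SY5Y cells (Homo sapiens) for cytotoxicity, read by MTT assay, with a stated time of 72 h (a higher number here means a weaker inhibitor, a lower number a stronger inhibitor), here. Compound 2 gives only a limit, not a number (the limit of > 1000 nM in this assay, at which 1 of the 3 values shown sits). Compound 3, at 620 nM in this assay, holds the higher of the two actual numbers, and compound 1 stands at 100 nM by comparison. Compound 4 `O=C1c2c[n+]([O-])c3ccccc3c2C(=O)c2c1c1ccccc1n2Cc1cn(C[C@@H](O)CO)nn1` carries 2,3-dihydroxypropyl in place of 4-hydroxy-5-(hydroxymethyl)oxolan-2-yl on an aromatic nitrogen. Going by the values given here, the only measured swap at such a nitrogen is an at least 1.6-fold lower number from compound 2 to compound 3 (0.20 log units; that floor lies within the scatter) and, with its floor inside the scatter, it offers a weak guide. No step beyond the scatter is therefore expected, and the expected change is a 1.1-fold higher number from compound 3 to compound 4 (0.05 log units; within the scatter) in this assay here. For compound 4 the estimated value is 700 nM, with an expected range from 300 nM to 1600 nM in this measurement.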

Compound 4, half-maximal inhibitory concentration: > 500 nM
Compound 4 was reported as a limit; the forecaster's own chance of this, stated with the estimate: 25%; the middle value does not contradict the limit.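

Compound 4 gives only a limit in this assay: the limit of > 500 nM in this assay, at which 1 of the 4 values shown sits. Even so, 1-(2,3-dihydroxypropyl)-1H-1,2,3-triazol-4-yl in place of 3-(4-methylpiperazin-1-yl)propyl gives an at least 5.0-fold higher number from compound 1 to compound 4 (0.69 log units; beyond the scatter), which shows that this change weakens the cytotoxic effect by more than the scatter.

Going by these compounds, the steps linking compound 4 to compound 2 and compound 3 cannot be read, so it remains open whether 2,3-dihydroxypropyl and 4-hydroxy-5-(hydroxymethyl)oxolan-2-yl differ on the aromatic nitrogen. Also open, on these data alone, is how a carboxylic acid or a simple amine at that nitrogen would compare.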